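A few compounds are considered here, and "the series" means these few. Any claim that something is new, unique, unknown or untested is made for them only; others in the source may bear on it.

Compound 1 `Nc1ccccc1NC(=O)c1ccc(CSC(=S)N2CCN(c3ccc(Cl)cc3)CC2)cc1` stands lowest of the three compounds measured in a functional assay on A-375 cells (Homo sapiens) for antiproliferative activity, read by CCK-8 assay, with a stated time of 72 h, tested at 8 uM (on this read-out lower numbers stand for a weaker effect and higher numbers for a stronger effect at the one concentration tested), where compound 1 gives 29%. Compound 2 `CN(C(=S)SCc1ccc(C(=O)Nc2ccccc2N)cc1)c1cccnc1` gives 87.7% and compound 3 `Nc1ccccc1NC(=O)c1ccc(CSC(=S)N2CCc3cc(Cl)ccc32)cc1` gives 82.3%. Among the compounds with values here, the one measured step, a number 5.4 percentage points lower from compound 2 to compound 3 (within the scatter), alters the group on the thiocarbonyl carbon and leaves the amine nitrogen in a ring untouched, so it does not bear on the change now in question. Compound 4 `Nc1ccccc1NC(=O)c1ccc(CSC(=S)N2CCN(c3ncccn3)CC2)cc1` differs from compound 1 by pyrimidin-2-yl in place of 4-chlorophenyl on an amine nitrogen in a ring. Within the data shown here, no measured step informs this change; compounds 2 and 3 show only that other groups on the thiocarbonyl carbon give high values. An uncertain step a number 21 percentage points higher from compound 1 to compound 4 (beyond the scatter) is therefore expected, and compound 4 is estimated at 50%, within 20% to 85%.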

Compound 4, a percentage reported as inhibition, at one concentration (the size of the read-out at that concentration, not a potency): 67.9%
The estimate for compound 4 lay 17.9 percentage points below the measured number; the measured number falls inside the stated range.
By their numbers in this assay, from the lowest: compound 1; then compound 4; then compounds 3 and 2 (each within the scatter of the next).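

In this assay the group on the amine nitrogen in a ring proves to matter on its own: with pyrimidin-2-yl in place of 4-chlorophenyl and the rest of the molecule unchanged, the step is a number 38.9 percentage points higher from compound 1 to compound 4 (beyond the scatter) and is large. No measurement shown here accounts for this step. An unsubstituted phenyl or a pyridin-2-yl group on the same nitrogen would separate the loss of the chlorine from the entry of the ring nitrogens. The compounds shown do not settle which of these two changes carries the step.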